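The source may hold more compounds than are shown below. What is called first, only, known or untested is meant among the compounds shown, and "the series" means these compounds.

Working notes on the urea series.

Three compounds that share one core and differ only in the aryl group on the triazole nitrogen have numbers in a functional assay on HepG2 cells (Homo sapiens) for inhibition, read by MTT assay, with a stated time of 72 h; a higher number here means a weaker inhibitor, a lower number a stronger inhibitor. Compound 1 `COc1cccc(-n2cc(COc3cccc(NC(=O)Nc4ccc(Cl)c(C(F)(F)F)c4)c3)nn2)c1` gives 1310 nM. Compound 2 `COc1ccc(-n2cc(COc3cccc(NC(=O)Nc4ccc(Cl)c(C(F)(F)F)c4)c3)nn2)cc1` gives 4680 nM. Compound 3 `CC(C)c1cccc(-n2cc(COc3cccc(NC(=O)Nc4ccc(Cl)c(C(F)(F)F)c4)c3)nn2)c1` gives 3250 nM, the second highest of the three numbers: its nearest neighbour is compound 2 and its furthest is compound 1. The measured steps are a 3.6-fold higher number from compound 1 to compound 2 (0.55 log units; beyond the scatter), a 2.5-fold higher number from compound 1 to compound 3 (0.39 log units; beyond the scatter) and a 1.4-fold lower number from compound 2 to compound 3 (0.16 log units; within the scatter).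

Compound 4 `O=C(Nc1cccc(OCc2cn(-c3ccc(C(F)(F)F)cc3)nn2)c1)Nc1ccc(Cl)c(C(F)(F)F)c1` is not yet measured. It differs from compound 3 by 4-(trifluoromethyl)phenyl in place of 3-isopropylphenyl on an aromatic nitrogen. Among the measured compounds shown here, the step that bears most on it is the one between compound 1 and compound 2, where a 3.6-fold higher number from compound 1 to compound 2 (0.55 log units; beyond the scatter) followed a move of the substituent from 3-methoxyphenyl to 4-methoxyphenyl. The step of a 1.4-fold lower number from compound 2 to compound 3 (0.16 log units; within the scatter) shows that exchanging the group itself mattered little. A 4-substituted phenyl is therefore expected to give a modestly higher number than compound 3, though a step within the scatter is possible. Compound 4 is estimated at 5000 nM, within 2000 nM to 13000 nM, meaning an expected step of a 1.5-fold higher number from compound 3 to compound 4 (0.19 log units; within the scatter).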

Compound 4, half-maximal inhibitory concentration: 1800 nM
Beside the measured number, compound 4's estimate is 2.8-fold (0.44 log units) above it; the whole stated range lies above it.
By their numbers in this assay, from the lowest: compounds 1, 4, 3 and 2 (each within the scatter of the next, the first and the last beyond it).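

In this assay, trifluoromethyl in place of methoxy on the 4-substituted phenyl separates the numbers, with a 2.6-fold lower number from compound 2 to compound 4 (0.41 log units; beyond the scatter). The 4-(trifluoromethyl)phenyl of compound 4 shows no step beyond the scatter against either group at the 3-position of the phenyl ring: a 1.8-fold lower number from compound 3 to compound 4 (0.26 log units; within the scatter) and a 1.4-fold higher number from compound 1 to compound 4 (0.14 log units; within the scatter). The higher number seen on moving methoxy from 3-methoxyphenyl to 4-methoxyphenyl therefore does not extend to every 4-substituted phenyl, and compound 4 goes against such a pattern.

No measurement at hand gives a reason for these steps. As far as these compounds go, whether an amine or a carboxylic acid on this phenyl ring would keep the number in the same range remains open, as does the effect of 3-(trifluoromethyl)phenyl on the aromatic nitrogen.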